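The compounds below may be only part of what the source reports. "The series", "measured", "known", "first", "only" and "open" are said of these compounds alone.

Measured in an ADME assay on MOLT-3 cells (Homo sapiens) for cytotoxicity, with a stated time of 7 days; on this read-out higher numbers stand for lower toxicity in this test and lower numbers for higher toxicity in this test:
compound 1 `COCCOc1nc(N)nc2c1ncn2/C=C1/CC1(CO)CO` gives > 20000 nM, a limit of the assay rather than a number.
compound 2 `CCCCCCCCOc1nc(N)nc2c1ncn2/C=C1/CC1(CO)CO` gives > 20000 nM, also a limit.
compound 3 `Nc1nc(NC2CCCC2)c2ncn(/C=C3/CC3(CO)CO)c2n1` gives > 20000 nM, again a limit.

Compound 3 therefore sits at the limit of > 20000 nM in this assay, at which 3 of the 3 values shown sit, and no number places it against the other two. The steps a step that the two limits leave unreadable from compound 1 to compound 3 and a step that the two limits leave unreadable from compound 2 to compound 3 are unreadable, as is a step that the two limits leave unreadable from compound 1 to compound 2. The change to compound 4 `Nc1nc(SCc2ccccc2)c2ncn(/C=C3/CC3(CO)CO)c2n1` is benzylsulfanyl in place of cyclopentylamino on an aromatic carbon. For the measured compounds named here, none of the measured steps bears readably on this change; the three limits give neither a direction nor a size for the expected step in this assay. Compound 4 is expected to stay at the limit, the step that the limit leaves unreadable from compound 3 to compound 4 being an estimate only. The estimate for compound 4 in this assay is 30000 nM, between 10000 nM and 100000 nM.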

Compound 4, half-maximal cytotoxic concentration: > 20000 nM
Compound 4 was reported as a limit; the forecaster's own chance of this, stated with the estimate: 80%; the middle value lies beyond the limit too.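

Compound 4 is a limit too, so no step among compound 1, compound 2, compound 3 and compound 4 can be read in this assay: the limit of > 20000 nM in this assay, at which 4 of the 4 values shown sit.

On these data alone, whether any of these groups on the shared core changes cytotoxicity remains open.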